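The compounds below may be only part of what the source reports. "The series", "measured", "known", "first", "only" and "open" are said of these compounds alone.

The measured compounds and their readings in a functional assay, tested at 2.5 mM; on this read-out lower numbers stand for less inhibition and higher numbers for more inhibition at the one concentration tested (going by the name of the read-out):

Compound 1 `CC(C)C[C@@H]1NC(=O)[C@H](Cc2cnc[nH]2)NC1=O` gives 0%.
Compound 2 `CC(C)C[C@@H]1NC(=O)[C@H](CCC(=O)O)NC1=O` gives 0%.
Compound 3 `CC(C)C[C@@H]1NC(=O)[C@H](CCC(N)=O)NC1=O` gives 0%.

Compound 3 stands level with its two neighbours in this assay: its nearest is compound 1 and its furthest is compound 2, and in both cases the difference lies within the scatter. The three measured steps, no change at the digits printed from compound 1 to compound 2 (within the scatter), no change at the digits printed from compound 1 to compound 3 (within the scatter) and no change at the digits printed from compound 2 to compound 3 (within the scatter), all leave the read-out unchanged, whether a carboxymethyl or a carbamoylmethyl replaces the 1H-imidazol-5-yl or an amino replaces the hydroxy on the carbonyl carbon.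

The next compound, compound 4 `CSCC[C@@H]1NC(=O)[C@H](CC(C)C)NC1=O`, differs from compound 3 as follows: methylsulfanyl in place of carbamoyl on a saturated chain carbon, two bonds along the chain from a saturated ring carbon. For the measured compounds named here, no measured step exchanges a carbamoyl for a methylsulfanyl, so none bears directly on this change. What the series does show is that three exchanges at the same side chain, no change at the digits printed from compound 1 to compound 2 (within the scatter), no change at the digits printed from compound 1 to compound 3 (within the scatter) and no change at the digits printed from compound 2 to compound 3 (within the scatter), all stayed within the scatter while every compound read at the floor of the assay.

On that basis compound 4 is expected to remain where compounds 1 to 3 sit, with the estimated step of no change at the digits printed from compound 3 to compound 4 (within the scatter) lying within the scatter. The estimate for compound 4 in this assay is therefore 0%, ranging from -8% to 10%.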

Compound 4, a percentage reported as inhibition, at one concentration (the size of the read-out at that concentration, not a potency): 0%
For compound 4 middle estimate and measured number coincide at the digits printed; low and high end bracket the measured number.
By their numbers in this assay, from the lowest: compounds 1, 2, 3 and 4 (each within the scatter of the next).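

In this assay, methylsulfanyl in place of carbamoyl on a saturated chain carbon, two bonds along the chain from a saturated ring carbon, gives no change at the digits printed from compound 3 to compound 4 (within the scatter), and methylsulfanyl in place of carboxy at the same place gives no change at the digits printed from compound 2 to compound 4 (within the scatter). For the compounds shown here, the flat reading therefore now extends to a side chain with a sulfur atom and 0 hydrogen-bond donors in the entering group, whereas the earlier compounds carried only imidazole, carboxy and carbamoyl ends, and the wider exchange of (methylsulfanyl)methyl in place of 1H-imidazol-5-yl on a saturated chain carbon bound to a saturated ring carbon likewise gives no change at the digits printed from compound 1 to compound 4 (within the scatter). No supporting data accompany these steps, so the reading stands as a bare observation.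

With all four compounds level at the same reading, the series gives no group at this position that moves the read-out, and it leaves open whether a primary amine, a phenyl ring or a longer alkyl chain there would do so. It also leaves open what a change in the other side chain of the shared core, the 2-methylpropyl group common to all four, would do to this reading.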